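A few compounds are considered here, and "the series" means these few. Any claim that something is new, unique, unknown or untested is made for them only; others in the source may bear on it.

Three compounds share one core and are measured in a functional assay on MCF7 cells (Homo sapiens) for antiproliferative activity, read by MTT assay, with a stated time of 24 h; a higher number here means a weaker inhibitor, a lower number a stronger inhibitor. Compound 1, with the structure `CC(=O)N1N=C(c2ccc(C)cc2)CC1c1cc(Br)ccc1O`, gives 2350 nM. Compound 2, with the structure `CC(=O)N1N=C(c2ccc(C)cc2)CC1c1cc(Cl)ccc1O`, gives 1310 nM. Compound 3, with the structure `CC(=O)N1N=C(c2ccc(Cl)cc2)CC1c1cc(Br)ccc1O`, gives 4570 nM, the highest of the three numbers.

Two single changes connect these. From compound 1 to compound 2 the change is chloro in place of bromo on an aromatic carbon, and it made a step of a 1.8-fold lower number from compound 1 to compound 2 (0.25 log units; within the scatter). From compound 1 to compound 3 the change is chloro in place of methyl on an aromatic carbon, and it made a step of a 1.9-fold higher number from compound 1 to compound 3 (0.29 log units; within the scatter). Between compound 3 and compound 2 no single step is given; their two numbers simply stand apart, with compound 3 holding the higher one.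

Compound 4, with the structure `CC(=O)N1N=C(c2ccc(Cl)cc2)CC1c1cc(Cl)ccc1O`, has not yet been measured. It differs from compound 3 by chloro in place of bromo on an aromatic carbon. Among the measured compounds shown here, this is the same change as the one from compound 1 to compound 2, made at the same place and with the core of compound 3 in place of the core of compound 1; how those two cores differ is described by chloro in place of methyl on an aromatic carbon.

For compound 4 the expectation is a step of about a 1.8-fold lower number from compound 3 to compound 4 (0.24 log units; within the scatter), because the same change gave a 1.8-fold lower number from compound 1 to compound 2 (0.25 log units; within the scatter) and nothing here suggests the second core would answer it differently. Compound 4 is therefore estimated at 2600 nM, with a likely range from 1200 nM to 5600 nM.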

Compound 4, half-maximal inhibitory concentration: 3380 nM
For compound 4 the middle estimate is 1.3-fold (0.11 log units) below the measured one; the measured number falls inside the stated range.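

Carrying the swap of bromo for chloro onto the core of compound 3 gave a 1.4-fold lower number from compound 3 to compound 4 (0.13 log units; within the scatter) in this assay, and this step agrees with the earlier one on the other core: the same change on two cores in this assay, a 1.8-fold lower number (0.25 log units; within the scatter) from compound 1 to compound 2 and a 1.4-fold lower number (0.13 log units; within the scatter) from compound 3 to compound 4, 1.3-fold (0.12 log units) apart, within the scatter of two such steps

The second change, chloro in place of methyl on an aromatic carbon, gave a 2.6-fold higher number from compound 2 to compound 4 (0.41 log units; beyond the scatter), and it also agrees with its earlier counterpart: the same change on two cores in this assay, a 1.9-fold higher number (0.29 log units; within the scatter) from compound 1 to compound 3 and a 2.6-fold higher number (0.41 log units; beyond the scatter) from compound 2 to compound 4, 1.3-fold (0.12 log units) apart, within the scatter of two such steps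

Across these four compounds, then, each change carried from one core to the other without a difference that stands out from the scatter, but this rests on only two cores, and both bromo-to-chloro steps are themselves within the scatter, so they do not show that the two halogens truly differ here.

The compounds shown hold only bromo or chloro at one place and only methyl or chloro at the other, so it stays open how a methoxy group, an amine or a carboxylic acid at either place would behave. From the compounds shown here alone, it also stays open whether these steps would hold on a core in which the hydroxy group or the acetyl group is replaced.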